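This account rests on a few compounds, and the source may have more. Where it says the series, first, only, none or still open, it means among the compounds named here.

Working notes on the series in an assay on isolated protein for inhibition of histone acetyltransferase KAT2B (Homo sapiens), read by fluorescence, with a stated time of 15 min; on this read-out higher numbers stand for weaker inhibition and lower numbers for stronger inhibition.

Compound 1 `CCn1c(=O)cc(Cl)[s+]1[O-]` carries an ethyl group on the ring nitrogen and a single chloro group on the shared core. In this assay compound 1 reaches only the limit > 10000 nM, so no number is known for it. Compound 2 `CCn1c(=O)c(Cl)c(Cl)[s+]1[O-]` adds a second chloro group. In this assay compound 2 likewise reaches only the limit > 10000 nM. Within the data shown here, the one measured step, a step that the two limits leave unreadable from compound 1 to compound 2, therefore cannot be sized; both values sit at the limit of > 10000 nM in this assay, at which 2 of the 2 values shown sit.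

Compound 3 `CCn1c(=O)c(C)c(Cl)[s+]1[O-]` differs from compound 2 by methyl in place of chloro on an aromatic carbon. Among the measured compounds shown here, no measured step touches this change: the only step in hand is unreadable, and compound 2 itself is known only as a limit. Nothing in the numbers shown points to a reading inside the measured range, so the expectation for compound 3 is that it too stays at the limit, with the step that the limit leaves unreadable from compound 2 to compound 3 expected to remain unresolved in this assay. The estimate for compound 3 in this assay is 20000 nM, within 5000 nM to 80000 nM.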

Compound 3, half-maximal inhibitory concentration: > 10000 nM
Compound 3 was reported as a limit; the forecaster's own chance of this, stated with the estimate: 85%; the middle value lies beyond the limit too.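

In this assay compound 3 gives > 10000 nM, which is a limit and not a number. No step among compound 1, compound 2 and compound 3 can be read, as all three stand at a limit: the limit of > 10000 nM in this assay, at which 3 of the 3 values shown sit.

The compounds shown leave open how hydrogen, chloro and methyl on that aromatic carbon rank, and whether any change to the shared core gives a measurable inhibition value.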